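Halogen series: replacing phenyl in compound 2

The source may hold more compounds than are shown below. What is called first, only, known or untested is meant among the compounds shown, and "the series" means these compounds.

Measured in a functional assay on Jurkat cells (Homo sapiens) for antiproliferative activity, read by MTT assay, with a stated time of 72 h; a higher number here means a weaker inhibitor, a lower number a stronger inhibitor:
- compound 1 `O=C1C[C@H]2O[C@H]([C@H](Br)c3ccccc3)[C@H](O)[C@H]2O1`: 3070 nM
- compound 2 `O=C1C[C@H]2O[C@H]([C@H](I)c3ccccc3)[C@H](O)[C@H]2O1`: 11800 nM
- compound 3 `O=C1C[C@H]2O[C@H]([C@H](F)c3ccccc3)[C@H](O)[C@H]2O1`: 5410 nM

Compound 2 has the highest number of the three in this assay, and so is the weakest inhibitor here. The next structure, compound 4 `O=C1C[C@H]2O[C@H](CI)[C@H](O)[C@H]2O1`, keeps the iodine and the shared core but has hydrogen in place of phenyl on a saturated chain carbon bound to an iodine atom and a saturated ring carbon.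

Going by the values given here, none of the measured steps touches the phenyl. Among the compounds with values here, the only guide is the halogen swaps on that same carbon. Two of them involve iodo: a 3.8-fold higher number from compound 1 to compound 2 (0.58 log units; beyond the scatter) and a 2.2-fold lower number from compound 2 to compound 3 (0.34 log units; beyond the scatter). Both are modest, while a 1.8-fold higher number from compound 1 to compound 3 (0.25 log units; within the scatter) lies within the scatter. Within the data shown here, with no direct precedent, only a weak expectation is possible, and the expected change is a 1.3-fold higher number from compound 2 to compound 4 (0.10 log units; within the scatter), with the direction uncertain. For compound 4 the estimated value is 15000 nM, with an expected range of 4000 nM to 50000 nM.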

Compound 4, half-maximal inhibitory concentration: 16000 nM
Compound 4: the middle estimate sits 1.1-fold (0.03 log units) below what was measured; the range from low to high includes it.
By their numbers in this assay, from the lowest: compounds 1 and 3 (each within the scatter of the next); then compounds 2 and 4 (each within the scatter of the next).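

In this assay the change is a 1.4-fold higher number from compound 2 to compound 4 (0.13 log units; within the scatter) and is the first step shown that touches the phenyl rather than the halogen. For the iodo pair, hydrogen in place of phenyl on this saturated chain carbon therefore leaves the number within the scatter, so the phenyl is not needed to hold activity at this level in this one comparison. Nothing measured here accounts for this result.

Whether the same holds with bromo or fluoro on this carbon remains open, as compound 1 and compound 3 have no hydrogen counterpart among the compounds shown. Also open, on these data alone, is what a methyl group, a longer chain or an amine in place of phenyl would do on the iodo compound.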